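This account rests on a few compounds, and the source may have more. Where it says the series, first, only, none or still open, it means among the compounds named here.

Within the data shown here, in a functional assay (mast cells) for inhibition, with Rattus norvegicus as the target (a lower number here means that less compound is needed, a higher number that more compound is needed for the effect), two compounds have numbers so far. Compound 1 (`C[C@H]1CC/C(=N\Nc2ccc(O)cc2)c2ncc(C(=O)O)c(=O)n21`) gives 26200 nM. Compound 2 (`CCOc1ccc(N/N=C2\CC[C@@H](C)n3c2ncc(C(=O)O)c3=O)cc1`) gives 1000 nM, the lower number of the pair, and the gap lies beyond the usual scatter. Compound 3 (`CCOc1ccc(N/N=C2\CC[C@H](C)n3c2ncc(C(=O)O)c3=O)cc1`) departs from compound 2 only at one centre: the two compounds have the same atoms and bonds and differ only in configuration as drawn: 1 of 2 stereo elements differ; a stereocentre at a saturated ring carbon is drawn R in compound 2 and S in compound 3. Among the measured compounds shown here, no measured pair isolates this stereocentre, so the direction is a tentative expectation, toward a lower number. The expected change is a 4.0-fold lower number from compound 2 to compound 3 (0.60 log units; beyond the scatter), and it may prove smaller. For compound 3 the estimated value is 250 nM, with an expected range of 40 nM to 1500 nM.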

Compound 3, half-maximal effective concentration: 19200 nM
Beside the measured number, compound 3's estimate is 77-fold (1.89 log units) below it; measured number outside the range, above it.
By their numbers in this assay, from the lowest: compound 2; then compounds 3 and 1 (each within the scatter of the next).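

In this assay this stereocentre at a saturated ring carbon carries a large effect: going from R to S gives a 19-fold higher number from compound 2 to compound 3 (1.28 log units; beyond the scatter). That step can be assigned to the stereocentre alone because of one thing: the fact that compounds 2 and 3 differ only in the configuration as drawn. With the centre drawn S, ethyl in place of hydrogen on an oxygen on an aromatic ring gives only a 1.4-fold lower number from compound 1 to compound 3 (0.14 log units; within the scatter). The compounds shown leave open how that ethyl reads with the centre drawn R. They also leave open whether a propyl chain on that oxygen, or an amide in place of the carboxylic acid, would hold the number of compound 2.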